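Diaryl ether thiosemicarbazones: lipophilicity notes toward compound 4

The source may hold more compounds than are shown below. What is called first, only, known or untested is meant among the compounds shown, and "the series" means these compounds.

Measured so far:
compound 1, `S=C(N/N=C/c1ccc(Oc2ccc(Br)cc2)cc1)Nc1ccc(Br)cc1`, in a physicochemical assay for lipophilicity, in phosphate buffer, measured as octanol-water partition, with a stated time of 24 h (on this read-out higher numbers stand for higher lipophilicity and lower numbers for lower lipophilicity), gives 6.53
compound 2, `Fc1ccc(Oc2ccc(/C=N/NC(=S)Nc3ccc(Cl)cc3)cc2)cc1`, in this assay gives 5.84
compound 3, `Fc1ccc(NC(=S)N/N=C/c2ccc(Oc3ccc(Br)cc3)cc2)cc1`, in this assay gives 5.88

Compound 3 stands second highest of the three numbers in this assay. Its nearest neighbour is compound 2, whose value lies within the scatter of it, so no order between those two can be claimed. Within the data shown here, compound 1 is the furthest; the one step that differs in a single place is a number 0.65 log units lower from compound 1 to compound 3 (beyond the scatter), a modest change beyond the scatter.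

Compound 4, `Cc1cc(Oc2ccc(/C=N/NC(=S)Nc3ccc(F)cc3)cc2)ccc1Cl`, differs from compound 3 at the diaryl ether side: 4-chloro-3-methylphenyl in place of 4-bromophenyl on an oxygen on an aromatic ring. Among the measured compounds shown here, no measured step touches this position; the only step in hand concerns the aryl on the thiourea nitrogen, so it gives no direct guide. On the partition coefficient as measured here, the change from 4-bromophenoxy to 4-chloro-3-methylphenoxy is expected to move the number only a little, if at all beyond the scatter, and if anything upward, as a number 0.27 log units higher from compound 3 to compound 4 (within the scatter). Compound 4 is therefore estimated at 6.15, with a range from 5.75 to 6.55.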

Compound 4, partition coefficient: 6.07
For compound 4 the middle estimate is 0.08 log units above the measured one; low and high end bracket the measured number.
By their numbers in this assay, from the lowest: compounds 2, 3 and 4 (each within the scatter of the next); then compound 1.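

The diaryl ether side now has its first measured step: in this assay there is a number 0.19 log units higher from compound 3 to compound 4 (within the scatter) for 4-chloro-3-methylphenyl in place of 4-bromophenyl on an oxygen on an aromatic ring. Among these compounds, this position therefore tolerates this exchange without a readable shift in the partition coefficient, whereas the only earlier step, a number 0.65 log units lower from compound 1 to compound 3 (beyond the scatter), concerned fluoro in place of bromo on an aromatic carbon. Nothing at hand explains the result at this position.

The single step changes the halogen and adds the methyl together, so the compounds shown do not separate the two contributions, and the small net step could equally be a sum of larger opposing ones or of two small ones. Also open, going by these compounds, is how this read-out would respond to a group of a different kind at the same place, such as an amine or a carboxylic acid on the phenoxy ring.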